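Swapping a difluorophenyl for a benzyloxy group on a carbonyl

A few compounds are considered here, and "the series" means these few. Any claim that something is new, unique, unknown or untested is made for them only; others in the source may bear on it.

Compound 1 `Cc1cc(C(=O)Nc2ccccc2)nn1Cc1cc(Cl)ccc1OCc1ccccc1` gives > 3.7 in a physicochemical assay for lipophilicity, at pH 7.4 (on this read-out higher numbers stand for higher lipophilicity and lower numbers for lower lipophilicity), a limit of the assay.
Compound 2 `CC(=O)Nc1cc(C)n(Cc2cc(Cl)ccc2OCc2ccccc2)n1` gives > 3.7 in this assay, a limit of the assay.
Compound 3 `Cc1cc(NC(=O)c2c(F)cccc2F)nn1Cc1cc(Cl)ccc1OCc1ccccc1` gives > 3.7 in this assay, a limit of the assay.

Compound 3 thus sits at the limit, as described by the limit of > 3.7 in this assay, at which 3 of the 3 values shown sit. The steps a step that the two limits leave unreadable from compound 1 to compound 2, a step that the two limits leave unreadable from compound 1 to compound 3 and a step that the two limits leave unreadable from compound 2 to compound 3 are all unreadable, so they give no size to learn from. Compound 4 `Cc1cc(NC(=O)OCc2ccccc2)nn1Cc1cc(Cl)ccc1OCc1ccccc1` differs from compound 3 by benzyloxy in place of 2,6-difluorophenyl on a carbonyl carbon. With every measured value at the limit, the step that the limit leaves unreadable from compound 3 to compound 4 is only an expectation of staying at or beyond it. Compound 4 is therefore expected near 4.2, between 3.7 and 4.8, most likely reported again as a limit.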

Compound 4, distribution coefficient: 3.1
Compound 4: the middle estimate sits 1.10 log units above what was measured; the whole stated range lies above it.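

Benzyloxy on this carbonyl carbon, in place of 2,6-difluorophenyl, gives the first measurable number in this assay, with a number at least 0.60 log units lower from compound 3 to compound 4 (beyond the scatter). The same group in place of methyl gives a number at least 0.60 log units lower from compound 2 to compound 4 (beyond the scatter), and (benzyloxycarbonyl)amino in place of phenylcarbamoyl gives a number at least 0.60 log units lower from compound 1 to compound 4 (beyond the scatter). The steps among compound 1, compound 2 and compound 3 cannot be read, and these new steps give only minimum sizes, because those three compounds are reported only as limits: the limit of > 3.7 in this assay, at which 3 of the 4 values shown sit.

The compounds shown leave open how an amine or a longer chain on this carbonyl carbon would read. They also leave open whether the oxygen or the ring of benzyloxy accounts for the step.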